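This account rests on a few compounds, and the source may have more. Where it says the series, first, only, none or still open, it means among the compounds named here.

Measured in an ADME assay on a cell-free system (plasma, Rattus norvegicus) for metabolic stability, read by LC-MS, with a stated time of 1 h, at 37 degrees C, tested at 100 uM; a higher number here means that more of the compound is left, a lower number that less of the compound is left
- compound 1 (`Cn1sc2cc(OCc3cccc(-c4ccc(Cl)c(C(=O)O)c4)c3)ccc2c1=O`) gives 100%
- compound 2 (`O=C(O)c1cc(-c2cccc(COc3ccc4c(c3)CN(C3CCCC3)C4=O)c2)ccc1O`) gives 98%
- compound 3 (`O=C(O)c1cc(-c2cccc(COc3ccc4c(=O)n(C5CCCC5)sc4c3)c2)ccc1F`) gives 100%

Compound 2, at 98% in this assay, stands level with the other two compounds, since all three values lie within the usual scatter of repeated measurements. These compounds differ from one another in more than one place, so the data offer no clean view of what a single change does here.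

The next compound to consider is compound 4 (`O=C(O)c1cc(F)cc(-c2cccc(COc3ccc4c(c3)CN(C3CCCC3)C4=O)c2)c1`). Its difference from compound 2 is a single swap, 3-carboxy-5-fluorophenyl in place of 3-carboxy-4-hydroxyphenyl on an aromatic carbon and in plain words, 3-carboxy-5-fluorophenyl takes the place of 3-carboxy-4-hydroxyphenyl on an aromatic carbon. The carboxy group stays, the hydroxy group leaves and a fluorine enters, while the rest of the molecule is unchanged.

Compound 3 also has a fluorine and no hydroxy group on the ring that holds its carboxy group, and compound 3 gives 100% in this assay. With that in view, no change beyond the scatter is expected. The expected result is no change at the digits printed from compound 2 to compound 4 (within the scatter) and is not thought to be a real shift in either direction. For compound 4 the estimated value is 98% with an expected range from 90% to 100% in this assay.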

Compound 4, percent of the compound remaining: 95%
Compound 4: middle estimate off by 3 percentage points, on the high side, within the range that was stated.
By their numbers in this assay, from the lowest: compounds 4, 2, 1 and 3 (each within the scatter of the next).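

In this assay, the swap of 3-carboxy-4-hydroxyphenyl for 3-carboxy-5-fluorophenyl on an aromatic carbon gives a number 3 percentage points lower from compound 2 to compound 4 (within the scatter). Going by these compounds alone, this is the first single change that can be read in this set, and it shows that, for this one pair, losing the hydroxy group and gaining a fluorine on the ring that holds the carboxy group leaves the amount of compound remaining the same within the usual scatter, with compound 4 still at 95% after the incubation. No measurement shown here offers an explanation for this result, so the finding remains a plain observation about one pair of compounds.

The hydroxy group leaves and the fluorine enters in the same swap, so the compounds shown leave open what each of these two changes does alone, and what a methoxy group or an amine on this ring would do. All four compounds also carry the carboxy group, so the data cannot tell how a nitrile or a primary amide in its place would behave in this assay.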